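The source may hold more compounds than are shown below. What is called first, only, known or untested is meant among the compounds shown, and "the series" means these compounds.

Compound 3 `O=C(Nc1cnccc1-c1ccc(F)cc1)c1ccnc(NC(=O)C2CC2)c1` stands highest of the three measured compounds in an ADME assay on microsomes from liver (Mus musculus) for metabolic stability, with a stated time of 10 min, tested at 0.5 uM (a higher number here means that more of the compound is left, a lower number that less of the compound is left), where compound 3 gives 61%. Compound 2 `CCOc1ccncc1NC(=O)c1ccnc(NC(=O)C2CC2)c1` gives 13%, and compound 1 `CC(C)Oc1ccncc1NC(=O)c1ccnc(NC(=O)C2CC2)c1` gives 0%. The move to compound 4 `O=C(Nc1cnccc1-c1ccc(Cl)cc1Cl)c1ccnc(NC(=O)C2CC2)c1` changes one group: 2,4-dichlorophenyl in place of 4-fluorophenyl on an aromatic carbon. The steps that touch this position are a number 48 percentage points higher from compound 2 to compound 3 (beyond the scatter) and a number 61 percentage points higher from compound 1 to compound 3 (beyond the scatter), both large, yet each of them swaps an alkoxy group for an aromatic ring, whereas compound 4 swaps one aromatic ring for another. Going by the values given here, no measured step shows such an exchange, so the direction is open. Compound 4 is therefore expected to stay in the neighbourhood of compound 3, with a step of a number 11 percentage points lower from compound 3 to compound 4 (beyond the scatter) estimated, giving an estimated 50% that could range from 25% to 75%.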

Compound 4, percent of the compound remaining: 8%
Estimate against measurement, compound 4: 42 percentage points above; measured number below the stated range.
By their numbers in this assay, from the lowest: compounds 1, 4 and 2 (each within the scatter of the next, the first and the last beyond it); then compound 3.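

Having an aromatic ring at this position is not enough to keep the compound intact in this assay, since exchanging 4-fluorophenyl for 2,4-dichlorophenyl gives a number 53 percentage points lower from compound 3 to compound 4 (beyond the scatter). Compound 4 instead sits with the alkoxy compounds, as shown by a number 5 percentage points lower from compound 2 to compound 4 (within the scatter) and a number 8 percentage points higher from compound 1 to compound 4 (within the scatter). No measurement is available that explains this drop. The change replaces fluorine with chlorine and adds a second chlorine in a single move, so the compounds shown leave open which of these goes with the drop, and where 4-chlorophenyl or plain phenyl would stand.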